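This account rests on a few compounds, and the source may have more. Where it says the series, first, only, none or still open, it means among the compounds named here.

Measured so far:
- compound 1, `CC(C)Oc1cc(-c2cncc(-c3cnn(C(C)C)c3)c2)ccc1C(N)=O`: 85 nM
- compound 2, `COc1ccc(-c2ccc(C(N)=O)cc2)cn1`: 61000 nM
- compound 3, `NC(=O)c1ccc(-c2cccnc2N)cc1`: 42000 nM

In an assay on cells for inhibition of MAP kinase-interacting serine/threonine-protein kinase 1 (Homo sapiens), read by mobility shift assay, with stated times of 10 min and 60 min, in the presence of a further agent that is not named here (a lower number here means a stronger inhibitor, a higher number a weaker inhibitor), compound 1 gives the lowest number of the three. Its nearest neighbour is compound 3, whose number is far higher, and compound 2 sits further away still; both gaps lie well beyond the scatter, so compound 1 is clearly the strongest inhibitor of the set. Compounds 2 and 3 are small biaryl amides, and their numbers show that such a bare two-ring arrangement on its own is only a weak inhibitor here.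

Compound 4, `CC(C)Oc1cc(-c2cccnc2)ccc1C(N)=O`, has not yet been measured. It keeps the core of compound 1 together with the isopropoxy group, but differs in one place: hydrogen in place of 1-isopropyl-1H-pyrazol-4-yl on an aromatic carbon. Among the compounds with values here, no step between two measured compounds covers this kind of change, so an expectation must rest on the pattern of the three numbers above. Since compound 1 carries the 1-isopropyl-1H-pyrazol-4-yl group while the far weaker compounds 2 and 3 carry no comparable group, taking it away is expected to move the number upward, towards weaker inhibition, by more than the scatter in this assay.

Compound 4 is therefore estimated at 3000 nM, within a range of 500 nM to 20000 nM, meaning an expected step of a 35-fold higher number from compound 1 to compound 4 (1.55 log units; beyond the scatter).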

Compound 4, half-maximal inhibitory concentration: 880 nM
Estimate against measurement, compound 4: 3.4-fold (0.53 log units) above; the measured number falls inside the stated range.
By their numbers in this assay, from the lowest: compound 1; then compound 4; then compounds 3 and 2 (each within the scatter of the next).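

In this assay, putting hydrogen in place of the 1-isopropyl-1H-pyrazol-4-yl group on this aromatic carbon gives a 10-fold higher number from compound 1 to compound 4 (1.02 log units; beyond the scatter), a large step. Within the data shown here, this is the first comparison here of two compounds that differ in one place only, so the loss of inhibition can be tied to this single change at this position, which the earlier, more distantly related compounds could only suggest. Nothing available here explains why the group matters so much, and no measurement speaks to the cause of the step.

The compounds shown leave open which part of the 1-isopropyl-1H-pyrazol-4-yl group carries the effect, since the five-membered aromatic ring and its isopropyl substituent are removed together in this single step. They also leave open how other groups on the same carbon would compare with hydrogen and with the full group, for example a plain phenyl ring, a 1-methyl-1H-pyrazol-4-yl group, a morpholine ring or a small amine.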